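Thiazol-2-yl in Place of Methoxyphenyl on a Diol Amide

This account rests on a few compounds, and the source may have more. Where it says the series, first, only, none or still open, it means among the compounds named here.

Of the compounds shown here, three have so far been measured in a functional assay on HCT-116 cells (Homo sapiens) for inhibition, read by colorimetric assay, with a stated time of 3 days; on this read-out lower numbers stand for stronger inhibition and higher numbers for weaker inhibition. Compound 1 `COc1ccc(-c2cnc(NC(=O)CCCCCCNC(=O)C(O)(O)C(F)(F)F)s2)cc1` gives 930 nM. Compound 2 `O=C(CCCCCCNC(=O)C(O)C(F)(F)F)Nc1nccs1` reaches only the limit of the assay, > 40000 nM. Compound 3 `COc1ccccc1NC(=O)CCCCCCNC(=O)C(O)(O)C(F)(F)F` gives 10100 nM, the highest of the two numbers recorded, with compound 1 standing well below it, beyond the usual scatter.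

Compound 4 `O=C(CCCCCCNC(=O)C(O)(O)C(F)(F)F)Nc1nccs1` has not yet been measured. It differs from compound 3 in one place: 1,3-thiazol-2-yl in place of 2-methoxyphenyl on an amide-type nitrogen. Among the compounds with values here, no measured pair shows this same change, so the direction of the step is open. Compound 4 is expected to give about 20000 nM in this assay, with a range from 5000 nM to 80000 nM. The estimated step of a 2.0-fold higher number from compound 3 to compound 4 (0.30 log units; within the scatter) would be a modest weakening, possibly not beyond the scatter.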

Compound 4, half-maximal inhibitory concentration: 10800 nM
Beside the measured number, compound 4's estimate is 1.9-fold (0.27 log units) above it; measured number inside the range.
By their numbers in this assay, from the lowest: compound 1; then compounds 3 and 4 (each within the scatter of the next). At a limit, above all of these: compound 2.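

In this assay, the ring on the amide-type nitrogen can be exchanged without a readable difference: a 1.1-fold higher number from compound 3 to compound 4 (0.03 log units; within the scatter). Hydroxy in place of hydrogen on the saturated chain carbon gives an at least 3.7-fold lower number from compound 2 to compound 4 (0.56 log units; beyond the scatter), a step read from a limit of the assay for compound 2. Far more rests on the aromatic carbon of the thiazole, where hydrogen in place of 4-methoxyphenyl gives a 12-fold higher number from compound 1 to compound 4 (1.06 log units; beyond the scatter). The compounds shown leave open whether a smaller group there, such as methyl or chlorine, would keep any of that difference. They also leave open how a longer chain would read.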